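A Chloro Substituent Carried Across Two Related Cores

A few compounds are considered here, and "the series" means these few. Any claim that something is new, unique, unknown or untested is made for them only; others in the source may bear on it.

Compound 1 `CC1CCN(c2c(S(=O)(=O)c3cccc(Cl)c3)cnc3ccc(Cl)cc23)CC1` and compound 2 `CC1CCN(c2c(S(=O)(=O)c3ccccc3)cnc3ccc(Cl)cc23)CC1` share one core; compound 3 `CC1CCN(c2c(S(=O)(=O)c3ccccc3)cnc3c(F)cccc23)CC1` and compound 4 `CC1CCN(c2c(S(=O)(=O)c3ccc(Cl)cc3)cnc3c(F)cccc23)CC1` share another, and the difference between the two cores is not broken down here. In an assay on isolated protein for displacement of a labelled ligand from metabotropic glutamate receptor 5 (Homo sapiens), with a stated time of 60 min, tested at 1 uM (a lower number here means less inhibition, a higher number more inhibition at the concentration tested (going by the name of the read-out)), compound 1 gives 92%, compound 2 gives 59% and compound 3 gives 13%. The change from compound 2 to compound 1 is chloro in place of hydrogen on an aromatic carbon, and it made a step of a number 33 percentage points higher from compound 2 to compound 1 (beyond the scatter). Compound 4 carries the same kind of change on the core of compound 3: chloro in place of hydrogen on an aromatic carbon. The place is not identical, since in compound 1 the chloro sits meta to a large group while in compound 4 it sits para to a large group. Going by the earlier step, a rise of a number 25 percentage points higher from compound 3 to compound 4 (beyond the scatter) is expected, tempered because the step of a number 33 percentage points higher from compound 2 to compound 1 (beyond the scatter) was measured on another core and at another place. Compound 4 is therefore estimated at 38%, with a likely range from 15% to 65%.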

Compound 4, a percentage reported as inhibition, at one concentration (the size of the read-out at that concentration, not a potency): 85%
Compound 4: middle estimate off by 47 percentage points, on the low side, and the stated range ends below it.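

On the core of compound 3, the change from phenyl to 4-chlorophenyl gave a number 72 percentage points higher from compound 3 to compound 4 (beyond the scatter) in this assay. The direction of the chloro step carried over from one core to the other, but its size did not: the same change on two cores in this assay, a number 33 percentage points higher (beyond the scatter) from compound 2 to compound 1 and a number 72 percentage points higher (beyond the scatter) from compound 3 to compound 4, 39 percentage points apart, beyond the scatter of two such steps

The two pairs differ both in the core and in the place of the chloro, so these results cannot show which of the two accounts for the gap. The compounds shown leave open how the chloro would behave if each core carried it at the place it holds on the other. They also leave open whether a methyl, a methoxy group or an amine at the same place would raise the number as well.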